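Amine tail variation on the shared core: working notes

The compounds below may be only part of what the source reports. "The series", "measured", "known", "first", "only" and "open" are said of these compounds alone.

Measured so far:
compound 1, `CN(C)CCCCOc1ccccc1/C=C/c1ccccc1Cl`, gives 14.3% in a functional assay on the whole organism with Mus musculus as the target, in the maximal electroshock model, at a dose of 50 mg/kg by the oral route; on this read-out higher numbers stand for more inhibition at the one dose given (going by the name of the read-out) and lower numbers for less inhibition
compound 2, `CCCN1CCN(CCCCOc2ccccc2/C=C/c2ccccc2)CC1`, gives 42.9% in this assay

Compound 2 holds the higher of the two numbers in this assay; compound 1 sits lower by a gap that is beyond the usual scatter. Within the data shown here, the two compounds differ in more than one place, so no single structural step between them is computed.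

Compound 3, `CC1CCCN(CCCCOc2ccccc2/C=C/c2ccccc2)C1`, has not yet been measured in this assay. Relative to compound 2 the change is 3-methylpiperidin-1-yl in place of 4-propylpiperazin-1-yl on a saturated chain carbon, four bonds along the chain from an oxygen on an aromatic ring. Both tails are saturated six-membered ring amines on the same chain, so on the numbers in hand no step beyond the scatter is expected in either direction; the step from compound 2 is estimated at a number 2.9 percentage points lower from compound 2 to compound 3 (within the scatter). For compound 3 in this assay the estimated value is 40%, with a range from 15% to 70%.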

Compound 3, a percentage reported as inhibition, in the whole organism at one dose (the size of the read-out at that dose, not a potency): 12.5%
The estimate for compound 3 lay 27.5 percentage points above the measured number, and the stated range ends above it.
By their numbers in this assay, from the lowest: compounds 3 and 1 (each within the scatter of the next); then compound 2.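

At this place, on a saturated chain carbon, four bonds along the chain from an oxygen on an aromatic ring, the tail is not interchangeable among saturated six-membered ring amines: 3-methylpiperidin-1-yl in place of 4-propylpiperazin-1-yl brings a number 30.4 percentage points lower from compound 2 to compound 3 (beyond the scatter) in this assay. This pair differs in one place, so sharing a ring size and a chain is not enough to hold the read-out. Nothing at hand bears on the reason for this step.

The change swaps several features at once, and the compounds shown leave open whether the step follows the second ring nitrogen, the propyl group or the methyl group. A plain piperidin-1-yl, a 4-methylpiperazin-1-yl or a morpholin-4-yl tail on the same chain would help separate these features.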